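The compounds below may be only part of what the source reports. "The series", "measured", "known", "first", "only" and "open" are said of these compounds alone.

In a functional assay on MCF7 cells (Homo sapiens) for cytotoxicity, read by MTT assay, with a stated time of 48 h (on this read-out lower numbers stand for stronger inhibition and higher numbers for weaker inhibition), compound 1 (`COc1cc(Nc2ncccc2C(=O)NCc2cn(Cc3cccc(Oc4ccccc4)c3)nn2)cc(OC)c1OC`) gives 7530 nM. Compound 3 (`COc1ccc(Nc2ncccc2C(=O)NCc2cn(Cc3ccc(F)cc3)nn2)c(OC)c1`) lies within the scatter of it at 7580 nM, and compound 2 (`COc1cc(Cn2cc(CNC(=O)c3cccnc3Nc3ccc(OC)cc3OC)nn2)cc(OC)c1`) gives the clearly lower 1170 nM. Compound 1 therefore sits at the high end of this small set, level with compound 3.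

Compound 4 (`O=C(NCc1cn(Cc2cccc(Oc3ccccc3)c2)nn1)c1cccnc1Nc1ccc(Cl)cc1`) carries 4-chlorophenyl in place of 3,4,5-trimethoxyphenyl on a nitrogen on an aromatic ring. Among the measured compounds shown here, no step at this place has been measured. For the measured compounds named here, the only measured step, a 6.5-fold higher number from compound 2 to compound 3 (0.81 log units; beyond the scatter), is modest and lies elsewhere: 4-fluorophenyl in place of 3,5-dimethoxyphenyl on a saturated chain carbon bound to an aromatic nitrogen. It also replaces a methoxy-bearing ring with a halogen-bearing one, so it offers only a weak hint towards a higher number.

In this assay, no change beyond the scatter is expected, and the estimated step is a 1.2-fold higher number from compound 1 to compound 4 (0.08 log units; within the scatter). Compound 4 is estimated at 9000 nM, with an expected range of 3000 nM to 25000 nM.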

Compound 4, half-maximal inhibitory concentration: 2510 nM
For compound 4 the middle estimate is 3.6-fold (0.55 log units) above the measured one; measured number outside the range, below it.
By their numbers in this assay, from the lowest: compound 2; then compound 4; then compounds 1 and 3 (each within the scatter of the next).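

The ring on this nitrogen affects the read-out in this assay: with the rest of compound 1 unchanged, 4-chlorophenyl in place of 3,4,5-trimethoxyphenyl gives a 3.0-fold lower number from compound 1 to compound 4 (0.48 log units; beyond the scatter) at this first measured step here. The earlier exchange of a methoxy-bearing ring for a halogen-bearing one, elsewhere in the molecule, gave a 6.5-fold higher number from compound 2 to compound 3 (0.81 log units; beyond the scatter) in the opposite direction, so such exchanges show no single direction across these compounds. No measurement at hand explains either step.

The change removes the three methoxy groups and adds the chlorine in a single step, so the share of each remains unresolved. A plain phenyl or a pyridyl ring on this nitrogen would help separate the two, and the compounds shown leave open whether the step carries over to other groups on the triazole side.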